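This account rests on a few compounds, and the source may have more. Where it says the series, first, only, none or still open, it means among the compounds named here.

Measured compounds:
compound 1 `COc1ccc(C(=O)/C=C/c2cc(-c3cc(OC)c(OC)c(OC)c3)n[nH]2)cc1OC`, in a functional assay on RXF 393 cells (Homo sapiens) for cytotoxicity, read by sulforhodamine B assay, with a stated time of 48 h, tested at 10 uM (a higher number here means a weaker effect of the compound at the concentration tested, a lower number a stronger effect), compound 1 gives -98%
compound 2 `COc1ccc(C(=O)/C=C/c2cc(-c3cc(OC)c(OC)c(OC)c3)n[nH]2)cc1`, in this assay compound 2 gives -97%

Among the compounds with values here, compound 2 holds the higher of the two numbers, with compound 1 as its only neighbour, and the step of a number 1 percentage points higher from compound 1 to compound 2 (within the scatter) is within the scatter: both compounds sit at a near-complete response at the tested concentration.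

Compound 3 `COc1cc(-c2cc(/C=C/C(=O)c3ccc(F)c(F)c3)[nH]n2)cc(OC)c1OC` is not yet measured. It differs from compound 2 by 3,4-difluorophenyl in place of 4-methoxyphenyl on a carbonyl carbon. Within the data shown here, no measured step concerns this swap. Among the measured compounds shown here, the one step available, a number 1 percentage points higher from compound 1 to compound 2 (within the scatter), shows that taking one methoxy off that ring changed nothing beyond the scatter, but it says nothing about replacing the remaining methoxy with fluorines. The working expectation is therefore a response of similar size, with a wider margin for a weaker effect, so the step of a number 12 percentage points higher from compound 2 to compound 3 (beyond the scatter) is expected to be small. Compound 3 is estimated at -85%, within -100% to -45%.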

Compound 3, a percentage reported as activity, at one concentration (the size of the read-out at that concentration, not a potency): -20%
The estimate for compound 3 lay 65 percentage points below the measured number; the whole stated range lies below it.
By their numbers in this assay, from the lowest: compounds 1 and 2 (each within the scatter of the next); then compound 3.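

In this assay, the group on the carbonyl carbon proves not to be indifferent: 3,4-difluorophenyl in place of 4-methoxyphenyl gives a number 77 percentage points higher from compound 2 to compound 3 (beyond the scatter), and 3,4-difluorophenyl in place of 3,4-dimethoxyphenyl gives a number 78 percentage points higher from compound 1 to compound 3 (beyond the scatter). Within the data shown here, the earlier pair showed only that this ring tolerates the loss of one methoxy; the new result shows that the near-complete response does not survive every replacement at this place. Nothing available explains the loss of response.

Still open, as far as these compounds go, is whether the drop follows the departure of the remaining methoxy or the arrival of the two fluorines. Plain phenyl, or a phenyl carrying a chlorine or a dimethylamino group on the carbonyl carbon, would help separate these two readings.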